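Removing a methyl from a phenol oxygen in a pyrazole series

The compounds below may be only part of what the source reports. "The series", "measured", "known", "first", "only" and "open" are said of these compounds alone.

Measured so far:
- compound 1, `COc1cc(C)cc(-c2c(-c3ccnc(-c4ccc(C(C)=O)cc4)c3)cnn2CC#N)c1`: 102%
- compound 2, `Cc1cc(O)cc(-c2nn(CC#N)cc2-c2ccnc(-c3ccc(Oc4ccccc4)cc3)c2)c1`: 110%
- compound 3, `COc1cc(C)cc(-c2nn(CC#N)cc2-c2ccnc(-c3ccc(N(C)C)cc3)c2)c1`: 106%

In a functional assay on OVCAR-4 cells (Homo sapiens) for cytotoxicity, read by sulforhodamine B assay, with a stated time of 48 h, tested at 0.001 uM (a lower number here means a stronger effect, a higher number a weaker effect of the compound at the concentration tested), compound 3 stands second highest of the three numbers, with compound 1 nearest and compound 2 furthest, both within the scatter of it. All three numbers sit close to the untreated level, so none of these compounds shows a clear effect at this concentration.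

Compound 4, `Cc1cc(O)cc(-c2nn(CC#N)cc2-c2ccnc(-c3ccc(N(C)C)cc3)c2)c1`, has not been measured yet. It differs from compound 3 in one place: hydrogen in place of methyl on an oxygen on an aromatic ring. For the measured compounds named here, compound 2 carries the same hydroxy group and gives 110%, and no compound here moves beyond the scatter.

The step of no change at the digits printed from compound 3 to compound 4 (within the scatter) is therefore expected to be none beyond the scatter. Compound 4 is estimated at 106%, ranging from 96% to 116%.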

Compound 4, a percentage reported as activity, at one concentration (the size of the read-out at that concentration, not a potency): 104%
Beside the measured number, compound 4's estimate is 2 percentage points above it, within the range that was stated.
By their numbers in this assay, from the lowest: compounds 1, 4, 3 and 2 (each within the scatter of the next).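

In this assay, for the compounds shown here, replacing methoxy with hydroxy gives a number 2 percentage points lower from compound 3 to compound 4 (within the scatter), the first direct comparison of the two groups on an otherwise identical compound, and it reveals no effect of removing the methyl at this concentration. Dimethylamino in place of phenoxy gives a number 6 percentage points lower from compound 2 to compound 4 (within the scatter), so this second change likewise shows nothing beyond the scatter. No other data bear on these results.

From the compounds shown here alone, whether either change matters at higher concentrations remains open, since these values all sit near the untreated level. Also open, going by these compounds, is how an amine or a carboxylic acid in place of the hydroxy group would behave.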